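Working notes: 4-methoxyphenyl to 3-methoxyphenyl

This account rests on a few compounds, and the source may have more. Where it says the series, first, only, none or still open, it means among the compounds named here.

Measured in a functional assay on SGC-7901 cells (Homo sapiens) for antiproliferative activity, read by MTT assay, with a stated time of 72 h; on this read-out higher numbers stand for weaker inhibition and lower numbers for stronger inhibition:
- compound 1 `COc1cc(-n2cnc3ccc(-c4ccc(C(C)=O)cc4)cc32)cc(OC)c1OC`: 450 nM
- compound 2 `COc1cc(-n2cnc3ccc(-c4cc(F)ccc4F)cc32)cc(OC)c1OC`: 6590 nM
- compound 3 `COc1ccc(-c2ccc3ncn(-c4cc(OC)c(OC)c(OC)c4)c3c2)cc1`: 82 nM

Compound 3 holds the lowest number of the three in this assay, at 82 nM. The next step leads to compound 4 `COc1cccc(-c2ccc3ncn(-c4cc(OC)c(OC)c(OC)c4)c3c2)c1`, with 3-methoxyphenyl in place of 4-methoxyphenyl on an aromatic carbon.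

Changes to this aryl group have already moved the number widely: a 5.5-fold lower number from compound 1 to compound 3 (0.74 log units; beyond the scatter) was modest, while a 15-fold higher number from compound 1 to compound 2 (1.17 log units; beyond the scatter) and an 80-fold lower number from compound 2 to compound 3 (1.91 log units; beyond the scatter) were large. Going by the values given here, none of these steps moves a methoxy group around the ring, so the data offer no direct precedent. The group stays the same here, so a modest step looks more likely than a large one. The direction is expected to be upward, as compound 3 at 82 nM already lies lowest.

The expected change is a 3.0-fold higher number from compound 3 to compound 4 (0.48 log units; beyond the scatter). For compound 4 the estimated value is 250 nM, with an expected range of 70 nM to 1000 nM.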

Compound 4, half-maximal inhibitory concentration: 3310 nM
Compound 4: middle estimate off by 13-fold (1.12 log units), on the low side; measured number outside the range, above it.
By their numbers in this assay, from the lowest: compound 3; then compound 1; then compounds 4 and 2 (each within the scatter of the next).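

In this assay, going by these compounds alone, moving the methoxy group on this aryl ring, with the same atoms joined differently, gives a 40-fold higher number from compound 3 to compound 4 (1.61 log units; beyond the scatter) as a large step, so placement alone matters at this position, which no earlier pair could show. The 3-methoxyphenyl group also gives a 7.4-fold higher number from compound 1 to compound 4 (0.87 log units; beyond the scatter) against the 4-acetylphenyl group, and the step of a 2.0-fold lower number from compound 2 to compound 4 (0.30 log units; within the scatter) leaves it not separated from the 2,5-difluorophenyl group, so the methoxy group does not by its presence alone secure the low number of compound 3. Nothing at hand explains the size of this positional step.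

This is the only positional pair shown. As far as these compounds go, whether a similar gap appears with a hydroxy or ethoxy group in place of methoxy on this ring remains open.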